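Urea to Amide at the Carbonyl of Compound 2

The source may hold more compounds than are shown below. What is called first, only, known or untested is meant among the compounds shown, and "the series" means these compounds.

Measured compounds:
compound 1 `O=C(Nc1cccc(-n2cc(-c3ccncc3)c(-c3cc(O)cc(Cl)c3)n2)c1)Nc1ccc(Cl)c(C(F)(F)F)c1` gives -9%
compound 2 `COc1cc(Cl)cc(-c2nn(-c3cccc(NC(=O)Nc4ccc(Cl)c(C(F)(F)F)c4)c3)cc2-c2ccncc2)c1` gives -51%
compound 3 `COc1cc(Cl)cc(-c2nn(-c3cccc(NC(=O)Nc4cc(C(F)(F)F)cc(C(F)(F)F)c4)c3)cc2-c2ccncc2)c1` gives -42%

These three compounds were run in a functional assay on K562 cells (Homo sapiens) for inhibition, read by sulforhodamine B assay, with a stated time of 48 h, tested at 100 uM; a higher number here means a weaker effect of the compound at the concentration tested, a lower number a stronger effect. Compound 2 stands lowest of the three numbers. Its nearest neighbour is compound 3, whose value lies within the scatter of it, so the two cannot be ordered. Compound 1 lies far above: the step of a number 42 percentage points lower from compound 1 to compound 2 (beyond the scatter) is large and beyond the scatter, and it goes with methyl in place of hydrogen on an oxygen on an aromatic ring.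

Compound 4 `COc1cc(Cl)cc(-c2nn(-c3cccc(NC(=O)c4cccc(C(F)(F)F)c4)c3)cc2-c2ccncc2)c1` has not been measured. It differs from compound 2 at the carbonyl carbon: 3-(trifluoromethyl)phenyl in place of (4-chloro-3-(trifluoromethyl)phenyl)amino on a carbonyl carbon

Among the compounds with values here, no measured step covers this kind of change. Within the data shown here, the one step known, from compound 1 to compound 2, concerns the oxygen on the other aromatic ring and leaves the urea untouched, so it says nothing about compound 4. Compound 3 shows only that another substitution pattern on the urea-side ring gives a value within the scatter of compound 2. With an amide in place of the urea, a weaker effect is expected, and the step of a number 31 percentage points higher from compound 2 to compound 4 (beyond the scatter) is estimated to reach beyond the scatter, though with wide uncertainty. Compound 4 is therefore expected to give about -20% in this assay, within a range from -50% to 10%.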

Compound 4, a percentage reported as activity, at one concentration (the size of the read-out at that concentration, not a potency): 32%
Estimate against measurement, compound 4: 52 percentage points below; the whole stated range lies below it.
By their numbers in this assay, from the lowest: compounds 2 and 3 (each within the scatter of the next); then compound 1; then compound 4.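

Within the data shown here, the carbonyl carbon of compound 2 proves to be a position where a single change moves the read-out a long way: in this assay the step of a number 83 percentage points higher from compound 2 to compound 4 (beyond the scatter) is large, and compound 4 gives 32% as the only positive number of the four, on the other side of zero from the three ureas. Among these compounds, the earlier compounds varied the oxygen on one aromatic ring and the substitution on the urea-side ring while all keeping the urea, and compound 4 is the first to show that 3-(trifluoromethyl)phenyl in place of (4-chloro-3-(trifluoromethyl)phenyl)amino on this carbonyl carbon removes the effect seen with compound 2. Nothing at hand explains why the effect is lost with this change.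

The change takes away the amino nitrogen, with its hydrogen-bond donor, and the chlorine in one move, and the compounds shown cannot tell which of the two goes with the step. A 4-chloro-3-(trifluoromethyl)phenyl group on the same carbonyl carbon would keep the chlorine without the amino nitrogen, and a (3-(trifluoromethyl)phenyl)amino group would keep the nitrogen without the chlorine, so either would part the two.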